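The compounds below may be only part of what the source reports. "The series", "measured", "known", "first", "only" and "open" are said of these compounds alone.

The measured compounds in a functional assay on MCF7 cells (Homo sapiens) for antiproliferative activity, read by MTT assay; on this read-out lower numbers stand for stronger inhibition and higher numbers for weaker inhibition:
compound 1 `COc1ccc(-c2ccnc(Nc3ccc(Cl)cc3Cl)n2)cc1` gives 4170 nM
compound 2 `Clc1ccc(Nc2nccc(-c3ccc(Br)cc3)n2)c(Cl)c1` gives 2490 nM
compound 3 `Clc1ccc(Nc2nccc(-c3ccc(Br)cc3)n2)cc1` gives 4180 nM

Compound 4 `COc1ccc(-c2ccnc(Nc3ccc(Cl)cc3)n2)cc1` has not yet been measured in this assay. It is derived from compound 3 by a single change, (methoxy in place of bromo on an aromatic carbon). The same change, at a place described in identical words, separates compound 2 from compound 1: methoxy in place of bromo on an aromatic carbon. There it produced a 1.7-fold higher number from compound 2 to compound 1 (0.22 log units; within the scatter). The two cores differ by hydrogen in place of chloro on an aromatic carbon, a change that gave a 1.7-fold higher number from compound 2 to compound 3 (0.22 log units; within the scatter). Compound 3 and compound 1 show numbers that are practically the same. For compound 4 a step of a 1.6-fold higher number from compound 3 to compound 4 (0.19 log units; within the scatter) is expected, resting on the earlier step of a 1.7-fold higher number from compound 2 to compound 1 (0.22 log units; within the scatter) in compound 2 and compound 1. Compound 4 is therefore estimated at 6500 nM, with a likely range from 3000 nM to 14000 nM.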

Compound 4, half-maximal inhibitory concentration: 810 nM
Compound 4: middle estimate off by 8.0-fold (0.90 log units), on the high side; the whole stated range lies above it.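

In this assay, methoxy in place of bromo gave a 5.2-fold lower number from compound 3 to compound 4 (0.71 log units; beyond the scatter), and this step does not match the one seen on the other core: the same change on two cores in this assay, a 1.7-fold higher number (0.22 log units; within the scatter) from compound 2 to compound 1 and a 5.2-fold lower number (0.71 log units; beyond the scatter) from compound 3 to compound 4, 8.6-fold (0.94 log units) apart, beyond the scatter of two such steps

Hydrogen in place of chloro gave a 5.1-fold lower number from compound 1 to compound 4 (0.71 log units; beyond the scatter), which likewise departs from its earlier step: the same change on two cores in this assay, a 1.7-fold higher number (0.22 log units; within the scatter) from compound 2 to compound 3 and a 5.1-fold lower number (0.71 log units; beyond the scatter) from compound 1 to compound 4, 8.6-fold (0.94 log units) apart, beyond the scatter of two such steps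

Across these four compounds, then, the step from either change depended on the core carrying it, so neither could be carried across; the data do not show why this happens, and one pair of cores says nothing about how further cores would behave.

The compounds shown leave open whether the result for compound 4 is particular to methoxy or would recur with an ethoxy group, a hydroxyl or an amine in that place.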